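A few compounds are considered here, and "the series" means these few. Any claim that something is new, unique, unknown or untested is made for them only; others in the source may bear on it.

Compound 1 `O=[N+]([O-])c1c(CS(=O)(=O)c2ccccc2)nc2c(-c3ccc(O)cc3)cc(Cl)cn12` is the starting point. In an ADME assay on HepG2 cells (Homo sapiens) for cytotoxicity, read by MTT assay, with a stated time of 72 h (a lower number here means that less compound is tolerated, a higher number that more compound is tolerated), compound 1 gives > 12500 nM, which is a limit of the assay rather than a number. Among the three compounds measured, compound 1 therefore stands only at a limit, and one further value is also a limit.

Compound 2 `O=[N+]([O-])c1c(CS(=O)(=O)c2ccccc2)nc2c(-c3ccc(CO)cc3)cc(Cl)cn12` gives 13100 nM in this assay. Compound 3 `O=[N+]([O-])c1c(CS(=O)(=O)c2ccccc2)nc2c(-c3ccc(C(F)(F)F)cc3)cc(Cl)cn12` gives > 3900 nM in this assay, again a limit. The step that the limit leaves unreadable from compound 1 to compound 2 and the step that the two limits leave unreadable from compound 1 to compound 3 cannot be sized, and the same holds for a step that the limit leaves unreadable from compound 2 to compound 3, since the limit of > 12500 nM in this assay, at which 1 of the 3 values shown sits, and the limit of > 3900 nM in this assay, at which 1 of the 3 values shown sits, hide where the true values lie.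

Compound 4 `O=[N+]([O-])c1c(CS(=O)(=O)c2ccccc2)nc2c(-c3ccccc3C(F)(F)F)cc(Cl)cn12` differs from compound 1 by 2-(trifluoromethyl)phenyl in place of 4-hydroxyphenyl on an aromatic carbon. The closest measured comparison is the step from compound 1 to compound 3, which is unreadable, so no direction beyond the scatter is expected for an at least 1.0-fold lower number from compound 1 to compound 4 (0.01 log units; that floor lies within the scatter). Compound 4 is estimated at 12000 nM, with a range from 4000 nM to 40000 nM, and a limit is again likely.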

Compound 4, half-maximal cytotoxic concentration: 22700 nM
Compound 4: the middle estimate sits 1.9-fold (0.28 log units) below what was measured, within the range that was stated.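

Within the data shown here, the one step that can be read is a 1.7-fold higher number from compound 2 to compound 4 (0.24 log units; within the scatter), so in this assay putting 2-(trifluoromethyl)phenyl at this position in place of 4-(hydroxymethyl)phenyl makes no difference that can be told from the usual scatter. Among these compounds, compound 4 is also the first compound here with a trifluoromethyl group on this phenyl ring to give a plain number rather than a limit. Compound 1 and compound 3 stand only at limits, so the steps from each of them to compound 4 cannot be read.

From the compounds shown here alone, whether 2-(trifluoromethyl)phenyl and 4-(trifluoromethyl)phenyl truly differ at this position stays open. Also open, going by these compounds, is how a phenyl ring carrying an amine or a carboxylic acid would behave here in this assay.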